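Moving a Phenyl Substituent: From Chloro to Cyano

The source may report more compounds than this note shows. Statements on the series, on what has been measured and on what is new or still open speak of the compounds shown alone.

The measured compounds and their values:
Compound 1, `COC(=O)C1=C(C)N=C(C)/C(=C(\O)OC)C1c1ccccc1Cl`, gives 2.19 nM.
Compound 2, `COC(=O)C1=C(C)N=C(C)/C(=C(\O)OC)C1c1cccc(Br)c1`, gives 1.29 nM.
Compound 3, `C=Cc1ccccc1C1C(C(=O)OC)=C(C)N=C(C)/C1=C(\O)OC`, gives 4.47 nM.

These three share a core and differ only in the aryl group on a saturated ring carbon. In a functional assay (muscle tissue) with Cavia porcellus as the target (a lower number here means that less compound is needed, a higher number that more compound is needed for the effect), compound 1 holds the second highest number of the three: compound 2 lies nearest, with a 1.7-fold lower number from compound 1 to compound 2 (0.23 log units; within the scatter), while compound 3 lies furthest, with a 2.0-fold higher number from compound 1 to compound 3 (0.31 log units; beyond the scatter).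

Compound 4, `COC(=O)C1=C(C)N=C(C)/C(=C(\O)OC)C1c1cccc(C#N)c1`, has not yet been measured. It differs from compound 1 in one place: 3-cyanophenyl in place of 2-chlorophenyl on a saturated ring carbon. Among the compounds with values here, the step that bears most on it is the one from compound 1 to compound 2, which also replaces 2-chlorophenyl with a phenyl carrying a single substituent and stayed within the scatter. The step to compound 3 is less related, since it changes the substituent on the aromatic carbon rather than its place. A step of a 1.1-fold lower number from compound 1 to compound 4 (0.04 log units; within the scatter) is therefore expected, most likely within the scatter. Compound 4 is estimated at 2 nM, with a range from 0.8 nM to 5.5 nM.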

Compound 4, half-maximal effective concentration: 34.7 nM
Compound 4: middle estimate off by 17-fold (1.24 log units), on the low side; the measured number lies above the stated range.
By their numbers in this assay, from the lowest: compounds 2 and 1 (each within the scatter of the next); then compound 3; then compound 4.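

In this assay, the identity of the group on the aromatic carbon matters, not only where it sits: cyano in place of bromo gives a 27-fold higher number from compound 2 to compound 4 (1.43 log units; beyond the scatter). The aryl group on the saturated ring carbon therefore allows less freedom than the first three compounds suggested, since 3-cyanophenyl in place of 2-chlorophenyl gives a 16-fold higher number from compound 1 to compound 4 (1.20 log units; beyond the scatter), and 3-cyanophenyl in place of 2-vinylphenyl gives a 7.8-fold higher number from compound 3 to compound 4 (0.89 log units; beyond the scatter). Nothing measured here offers a reason for these rises.

As far as these compounds go, whether the higher number belongs to the nitrile wherever it stands, or only to the nitrile in the 3-cyanophenyl arrangement, remains open, and a 2-cyanophenyl group would test that. From the compounds shown here alone, how a phenyl group carrying an amine or a carboxylic acid at that same carbon would behave also remains open.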